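A few compounds are considered here, and "the series" means these few. Any claim that something is new, unique, unknown or untested is made for them only; others in the source may bear on it.

Measured in a functional assay on HL-60 cells (Homo sapiens) for cytotoxicity, read by WST assay, with a stated time of 48 h; on this read-out higher numbers stand for weaker inhibition and lower numbers for stronger inhibition:
- compound 1 `COC[C@H](C(C)C)C(c1ccc(O)c(OC)c1)c1ccc(O)c(OC)c1`: 72000 nM
- compound 2 `COc1cc(C(c2ccc(O)c(OC)c2)[C@@H](C)C(C)C)ccc1O`: 20000 nM
- compound 3 `COC[C@@H](C)[C@@H](C)C(c1ccc(O)c(OC)c1)c1ccc(O)c(OC)c1`: 85000 nM

Compound 3 sits at 85000 nM. The data show a 1.2-fold higher number from compound 1 to compound 3 (0.07 log units; within the scatter), so these two cannot be told apart. They also show a 4.3-fold higher number from compound 2 to compound 3 (0.63 log units; beyond the scatter), which places compound 2 clearly lower.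

The next compound is compound 4 `COc1cc(C(c2ccc(O)c(OC)c2)[C@H](CO)C(C)C)ccc1O`, and the change is 1-(hydroxymethyl)-2-methylpropyl in place of 2-(methoxymethyl)-1-methylpropyl on a saturated chain carbon bound to two aromatic carbons. In words, 1-(hydroxymethyl)-2-methylpropyl replaces 2-(methoxymethyl)-1-methylpropyl on a saturated chain carbon bound to two aromatic carbons.

Among the measured compounds shown here, no measured compound carries this hydroxymethyl group, so the guidance is indirect. Exchanging one methoxymethyl-bearing group for the other gave a 1.2-fold higher number from compound 1 to compound 3 (0.07 log units; within the scatter), which suggests that the change in chain arrangement alone need not shift the number. Removing the oxygen-bearing arm altogether gave a 3.6-fold lower number from compound 1 to compound 2 (0.56 log units; beyond the scatter), and this is the only modest drop on record. Compound 4 still keeps one oxygen in its group, so a smaller drop than that one is expected, probably no larger than the scatter.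

The expected change is a 1.5-fold lower number from compound 3 to compound 4 (0.19 log units; within the scatter). For compound 4 the estimated value is 55000 nM, with an expected range from 20000 nM to 130000 nM.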

Compound 4, half-maximal inhibitory concentration: > 100000 nM
Compound 4: no number, only a limit; the forecaster's own chance of this, stated with the estimate: 10%; middle value at least 1.8-fold (0.25 log units) away from the limit.
By their numbers in this assay, from the lowest: compound 2; then compounds 1 and 3 (each within the scatter of the next). At a limit, above all of these: compound 4.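

Compound 4 has no exact number in this assay, only a limit: the limit of > 100000 nM in this assay, at which 1 of the 4 values shown sits.

Replacing the methyl on the oxygen with hydrogen gives an at least 1.3-fold higher number from compound 1 to compound 4 (0.14 log units; that floor lies within the scatter), and the comparison with the other methoxymethyl-bearing group gives an at least 1.1-fold higher number from compound 3 to compound 4 (0.07 log units; that floor lies within the scatter), so neither floor separates the free hydroxymethyl group from these two ether-bearing groups. The firmer result comes from the comparison with the plain 1,2-dimethylpropyl group, which shows an at least 5.0-fold higher number from compound 2 to compound 4 (0.69 log units; beyond the scatter); all three groups with an oxygen in this side chain now give higher readings than the one group without it, and no compound shown goes against this.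

The limit leaves open how weak compound 4 really is, and so whether the free hydroxymethyl group differs from the methoxymethyl-bearing groups at all. As far as these compounds go, it also remains unknown whether an amine or a carboxylic acid in place of the hydroxyl would follow the same pattern, or whether a longer all-carbon chain on this saturated carbon would give a lower number than the 1,2-dimethylpropyl group.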